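The source may hold more compounds than are shown below. What is called first, only, known or untested is meant among the compounds shown, and "the series" means these compounds.

Compound 1 `COc1ccc(-c2[nH]c3ccccc3c2/C=C(\C#N)S(=O)(=O)c2ccccc2)cc1`: 554 nM
Compound 2 `COc1ccc(-c2[nH]c3ccc(OC)cc3c2C=C(C#N)C#N)cc1`: 778 nM

In a functional assay on HCT-15 cells (Homo sapiens) for inhibition, read by sulforhodamine B assay, with a stated time of 48 h (on this read-out lower numbers stand for stronger inhibition of growth and higher numbers for weaker inhibition of growth), compound 1 gives the lower of the two numbers, but compound 2 lies within the usual scatter of it, so the two cannot be ranked against each other. Compound 3 `N#C/C(=C\c1c(-c2ccccc2)[nH]c2ccccc12)S(=O)(=O)c1ccccc1` differs from compound 1 by hydrogen in place of methoxy on an aromatic carbon. For the measured compounds named here, no measured pair shows this change on its own, so its size is not known from the data. The step from compound 1 to compound 3 is expected to be small, a 1.4-fold higher number from compound 1 to compound 3 (0.16 log units; within the scatter), without a clear direction beyond the scatter. Compound 3 is therefore estimated at 800 nM, with a range from 300 nM to 2500 nM.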

Compound 3, concentration for 50% growth inhibition: 1100 nM
Beside the measured number, compound 3's estimate is 1.4-fold (0.14 log units) below it; measured number inside the range.
By their numbers in this assay, from the lowest: compounds 1, 2 and 3 (each within the scatter of the next).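

Going from 4-methoxyphenyl to phenyl now has a measured size: this assay shows a 2.0-fold higher number from compound 1 to compound 3 (0.30 log units; within the scatter) for this pair. The methoxy on this aromatic carbon, para to a large group, can thus be replaced by hydrogen without a step that stands clear of the scatter, so no direction can be assigned to it. Nothing available explains this result.

The compounds shown leave open whether an amine, a hydroxyl or a longer chain such as ethoxy at this place would give a step beyond the scatter.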